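This account rests on a few compounds, and the source may have more. Where it says the series, first, only, none or still open, it means among the compounds named here.

Compound 1, `CN1C/C(=C\c2ccc(Cl)cc2)C(=O)[C@]2(C1)[C@@H](c1ccc(Cl)cc1)CN(C)[C@@]21C(=O)Nc2ccccc21`, gives 42.2% in a functional assay on the whole organism (strain Wister albino) for inhibition, with Rattus norvegicus as the target, read by paw edema, with stated times of 1 h and 4 h, at a dose of 50 mg/kg by the intraperitoneal route; on this read-out higher numbers stand for more inhibition at the one dose given (going by the name of the read-out) and lower numbers for less inhibition.
Compound 2, `CN1C/C(=C\c2ccc(Cl)cc2)C(=O)[C@]2(C1)[C@@H](c1ccc(Cl)cc1)CN(C)[C@@]21C(=O)N(C)c2ccccc21`, gives 45.7% in this assay.
Compound 3, `CN1C/C(=C\c2ccc(-c3cccs3)cc2)C(=O)[C@]2(C1)[C@@H](c1ccc(-c3cccs3)cc1)CN(C)[C@@]21C(=O)Nc2ccccc21`, gives 71.4% in this assay.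

Compound 2 differs from compound 1 only by methyl in place of hydrogen on an amide-type nitrogen in a ring. The step this change made, a number 3.5 percentage points higher from compound 1 to compound 2 (within the scatter), is of the kind that repeated measurements of one and the same compound can show, so the two values are best read as alike.

Compound 3 has a different core from compound 1; the difference between the two cores is not broken down here. Its value in this assay lies beyond the scatter above both compound 1 and compound 2, so among the three measured compounds it shows the most inhibition.

Compound 4, `CN1C/C(=C\c2ccc(-c3cccs3)cc2)C(=O)[C@]2(C1)[C@@H](c1ccc(-c3cccs3)cc1)CN(C)[C@@]21C(=O)N(C)c2ccccc21`, is not yet measured. Among the compounds with values here, it differs from compound 3 by methyl in place of hydrogen on an amide-type nitrogen in a ring, which is the same change, at the same place, as the one from compound 1 to compound 2. Within the data shown here, the only guide to its effect is that earlier step, a number 3.5 percentage points higher from compound 1 to compound 2 (within the scatter), which stayed within the scatter. The same small step is therefore expected here, a number 2.6 percentage points higher from compound 3 to compound 4 (within the scatter), because compound 3 starts from 71.4% and the change on the core of compound 1 moved the value only by a number 3.5 percentage points higher from compound 1 to compound 2 (within the scatter). Compound 4 is accordingly expected to give about 74% in this assay, with a likely range from 62% to 84%.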

Compound 4, a percentage reported as inhibition, in the whole organism at one dose (the size of the read-out at that dose, not a potency): 69.8%
The estimate for compound 4 lay 4.2 percentage points above the measured number; low and high end bracket the measured number.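

On the core of compound 3, methyl in place of hydrogen on the amide-type nitrogen gave a number 1.6 percentage points lower from compound 3 to compound 4 (within the scatter), so the two compounds are best read as alike in this assay. Set beside the earlier step on the core of compound 1, the change behaves in the same way on both cores, with no real difference between the two steps: the same change on two cores in this assay, a number 3.5 percentage points higher (within the scatter) from compound 1 to compound 2 and a number 1.6 percentage points lower (within the scatter) from compound 3 to compound 4, 5.1 percentage points apart, within the scatter of two such steps This shows that, for these two cores, the amide hydrogen can give way to a methyl without a clear shift in the inhibition seen at this one dose, but it rests on only two pairs of compounds and does not show that the same would hold on any other core, at another dose or in another kind of test.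

From the compounds shown here alone, whether a larger group on that nitrogen, such as a benzyl or a longer chain ending in an amine, would also leave the value in place remains open. Also open is what a single swap on the core would do, for instance a fluorine or a methoxy in place of one chlorine, as the two cores shown differ in more than one place.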